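Swapping Acetyl for Dimethylamino: Expected Effect on Cytotoxicity

The compounds below may be only part of what the source reports. "The series", "measured", "known", "first", "only" and "open" are said of these compounds alone.

Of the compounds shown here, three have so far been tested in a functional assay on UO-31 cells (Homo sapiens) for cytotoxicity, read by sulforhodamine B assay, with a stated time of 48 h, tested at 0.01 uM; a lower number here means a stronger effect, a higher number a weaker effect of the compound at the concentration tested. Compound 1 `COc1cc(C)cc(-c2c(-c3ccnc(-c4ccc(C(C)=O)cc4)c3)cnn2CC#N)c1` gives 87% in this assay. Compound 2 `Cc1cc(O)cc(-c2nn(CC#N)cc2-c2ccnc(-c3ccc(Oc4ccccc4)cc3)c2)c1` gives 85%, and compound 3 `COc1cc(C)cc(-c2nn(CC#N)cc2-c2ccnc(-c3ccc(N(C)C)cc3)c2)c1` gives 92%. On these numbers compound 1 stands second highest of the three, but its value lies within the scatter of both compound 2 and compound 3, so no order among them can be read. Compound 4 `COc1cc(C)cc(-c2c(-c3ccnc(-c4ccc(N(C)C)cc4)c3)cnn2CC#N)c1` has not yet been measured in this assay. It differs from compound 1 by dimethylamino in place of acetyl on an aromatic carbon. Compound 3 already carries the dimethylamino group and gives 92%, within the scatter of compound 1, so the step of a number 3 percentage points higher from compound 1 to compound 4 (within the scatter) is expected to be none beyond the scatter. Compound 4 is therefore estimated at 90%, with a range from 78% to 99%.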

Compound 4, a percentage reported as activity, at one concentration (the size of the read-out at that concentration, not a potency): 63%
Compound 4: the middle estimate sits 27 percentage points above what was measured, outside the stated range (below it).
By their numbers in this assay, from the lowest: compound 4; then compounds 2, 1 and 3 (each within the scatter of the next).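

Swapping acetyl for dimethylamino in this assay gives a number 24 percentage points lower from compound 1 to compound 4 (beyond the scatter) and is the first step here between compounds that differ in one place. It shows that the substituent at this position, on an aromatic carbon para to a large group, can change the read-out beyond the scatter. No measurement given here bears on the origin of this step.

As far as these compounds go, it remains open whether the step follows from losing acetyl or from gaining dimethylamino. Also open, from the compounds shown here alone, is how a smaller amine, a morpholine ring or a carboxylic acid would behave at this position.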